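The source may hold more compounds than are shown below. What is called first, only, known or untested is meant among the compounds shown, and "the series" means these compounds.

Three compounds share one core and differ only in the group attached to a carbonyl carbon. In an ADME assay on microsomes from liver (Homo sapiens) for metabolic stability, read by LC-MS, using NADPH, with a stated time of 45 min, tested at 1 uM (a lower number here means that the compound disappears faster, a higher number that the compound lasts longer), compound 1 `COCCOC(=O)c1cc(N)c(Nc2ccc(C#N)cc2)cc1Oc1c(C)cc(/C=C/C#N)cc1C` gives 0.317 h, compound 2 `CCNC(=O)c1cc(N)c(Nc2ccc(C#N)cc2)cc1Oc1c(C)cc(/C=C/C#N)cc1C` gives 2.32 h, and compound 3 `Cc1cc(/C=C/C#N)cc(C)c1Oc1cc(Nc2ccc(C#N)cc2)c(N)cc1C(=O)NN` gives 0.6 h. Compound 3 thus stands second highest of the three: its number is close to that of compound 1, as the step of a 1.9-fold higher number from compound 1 to compound 3 (0.28 log units; within the scatter) shows, while the step of a 3.9-fold lower number from compound 2 to compound 3 (0.59 log units; beyond the scatter) lies beyond the scatter. The step of a 7.3-fold higher number from compound 1 to compound 2 (0.86 log units; beyond the scatter) is the largest among the measured pairs.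

Compound 4 `Cc1cc(/C=C/C#N)cc(C)c1Oc1cc(Nc2ccc(C#N)cc2)c(N)cc1C(=O)N1CC1` is not yet measured. It differs from compound 3 in one place: aziridin-1-yl in place of aminoamino on a carbonyl carbon. Among the measured compounds shown here, no measured step swaps in a ring at this position, so the bearing of the earlier steps is indirect. The steps from compound 1 and from compound 3 to compound 2 show that this position can move the number in this assay by a modest amount. For compound 4 a small rise, likely within the scatter, is expected, giving the step of a 1.7-fold higher number from compound 3 to compound 4 (0.22 log units; within the scatter). The estimate for compound 4 in this assay is 1 h, with a range from 0.4 h to 2.5 h.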

Compound 4, half-life: 2.63 h
Compound 4: the middle estimate sits 2.6-fold (0.42 log units) below what was measured; the whole stated range lies below it.
By their numbers in this assay, from the lowest: compounds 1 and 3 (each within the scatter of the next); then compounds 2 and 4 (each within the scatter of the next).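

Among the compounds shown here, compound 4 is the first amide in this set with no hydrogen on the amide nitrogen, yet aziridin-1-yl in place of aminoamino gives a 4.4-fold higher number from compound 3 to compound 4 (0.64 log units; beyond the scatter) in this assay, and the same ring in place of 2-methoxyethoxy gives an 8.3-fold higher number from compound 1 to compound 4 (0.92 log units; beyond the scatter). Against ethylamino, it gives a 1.1-fold higher number from compound 2 to compound 4 (0.05 log units; within the scatter), so the amide hydrogen is not required to reach the level of compound 2, and a small ring at this carbonyl carbon serves as well as the open ethylamino group. The data shown offer no measured explanation for these differences in half-life.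

The compounds shown cannot separate the presence of the ring from the loss of the amide hydrogen, a question that dimethylamino, with no ring and no amide hydrogen, would address. As far as these compounds go, whether larger rings such as pyrrolidin-1-yl or morpholin-4-yl behave like aziridin-1-yl also remains open.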